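Swapping Methoxycarbonyl for tert-Butyl on the Aromatic Ring

The source may hold more compounds than are shown below. What is called first, only, known or untested is meant among the compounds shown, and "the series" means these compounds.

Three compounds share one core and differ only in the group on a six-membered aromatic ring of carbon only. Compound 1 `CN1CCC[C@@H]1Cn1nc(Cc2ccc(O)cc2)c2ccccc2c1=O` carries a hydroxy group there, and in an assay for binding affinity to Alpha-1B adrenergic receptor (Homo sapiens) (a lower number here means a stronger inhibitor, a higher number a weaker inhibitor), compound 1 gives 398 nM. Compound 2 `COc1ccc(Cc2nn(C[C@H]3CCCN3C)c(=O)c3ccccc23)cc1` carries a methoxy group instead, and in this assay compound 2 gives 158 nM, a step of a 2.5-fold lower number from compound 1 to compound 2 (0.40 log units; beyond the scatter). Compound 3 `COC(=O)c1ccc(Cc2nn(C[C@H]3CCCN3C)c(=O)c3ccccc23)cc1` carries a methoxycarbonyl group. For compound 3 in this assay the assay reports only a limit, > 1990 nM, and among the three measured values it is the only one sitting there (the limit of > 1990 nM in this assay, at which 1 of the 3 values shown sits). Compound 3 therefore stands at the weak end: the step of an at least 5.0-fold higher number from compound 1 to compound 3 (0.69 log units; beyond the scatter) and the step of an at least 12-fold higher number from compound 2 to compound 3 (1.10 log units; beyond the scatter) both mark a clear loss on going to methoxycarbonyl.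

Compound 4 `CN1CCC[C@@H]1Cn1nc(Cc2ccc(C(C)(C)C)cc2)c2ccccc2c1=O` differs from compound 3 by tert-butyl in place of methoxycarbonyl on an aromatic carbon. Within the data shown here, no measured step involves tert-butyl, so the expectation rests on the two steps into compound 3, which show that methoxycarbonyl is the costly group; removing it is expected to lower the number in this assay, though tert-butyl differs from both hydroxy and methoxy and the gain is uncertain. The expected step is an at least 3.3-fold lower number from compound 3 to compound 4 (0.52 log units; beyond the scatter). Compound 4 is estimated to give about 600 nM, with a range from 150 nM to 2500 nM.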

Compound 4, inhibition constant: > 1990 nM
Compound 4: a limit, no number; the forecaster's own chance of this, stated with the estimate: 25%; middle value at least 3.3-fold (0.52 log units) from the limit.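

Compound 4 stands at a limit of the assay and not at a number, as compound 3 does, so the step between them cannot be read: the limit of > 1990 nM in this assay, at which 2 of the 4 values shown sit.

Among these compounds, what is new is that methoxycarbonyl is not the only group at this place to end up at the weak end of this assay, since tert-butyl shows an at least 12-fold higher number from compound 2 to compound 4 (1.10 log units; beyond the scatter) and an at least 5.0-fold higher number from compound 1 to compound 4 (0.69 log units; beyond the scatter). The two groups share a count of 4 heavy atoms, yet methoxycarbonyl has 2 hydrogen-bond acceptors and tert-butyl has none, so having acceptors is not what these two groups have in common.

Only hydroxy and methoxy give readable numbers here, and a group such as ethyl, a chlorine atom or an amine at the same place would show whether readable values stop short of tert-butyl. The compounds shown also leave open how compound 3 and compound 4 rank against each other, and whether the same loss appears when the shared core is changed elsewhere.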